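The source may hold more compounds than are shown below. What is called first, only, known or untested is meant among the compounds shown, and "the series" means these compounds.

Measured compounds in an assay on CHO-K1 cells for displacement of a labelled ligand from adenosine receptor A1 (Homo sapiens), read by scintillation counting, with a stated time of 60 min; a lower number here means a stronger inhibitor, a higher number a weaker inhibitor:
- compound 1 `Nc1nc(N/N=C/c2ccc(Br)cn2)nc2c1ncn2[C@@H]1O[C@H](CO)[C@@H](O)[C@H]1O`: 4.7 nM
- compound 2 `Nc1nc(N/N=C/c2ccc(Cl)c(C(F)(F)F)c2)nc2c1ncn2[C@@H]1O[C@H](CO)[C@@H](O)[C@H]1O`: reported only as a limit of the assay, > 10000 nM
- compound 3 `Nc1nc(N/N=C/C2CCCC2)nc2c1ncn2[C@@H]1O[C@H](CO)[C@@H](O)[C@H]1O`: 5.6 nM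

Compound 3 holds the highest of the two numbers shown, but its nearest neighbour compound 1 differs only by a 1.2-fold higher number from compound 1 to compound 3 (0.08 log units; within the scatter), so the two are not separated. The third value is the limit (the limit of > 10000 nM in this assay, at which 1 of the 3 values shown sits), belonging to compound 2.

Compound 4 `CCCOc1ccc(/C=N/Nc2nc(N)c3ncn([C@@H]4O[C@H](CO)[C@@H](O)[C@H]4O)c3n2)cc1` is not yet measured. Its change from compound 3 is 4-propoxyphenyl in place of cyclopentyl on a carbon with a double bond to nitrogen.

For the measured compounds named here, two measured steps bear on this. The step of an at least 2100-fold higher number from compound 1 to compound 2 (3.32 log units; beyond the scatter) shows a six-membered aromatic ring of carbon only entering on this carbon with a very large loss, and an at least 1700-fold lower number from compound 2 to compound 3 (3.25 log units; beyond the scatter) shows the same ring leaving for cyclopentyl with an equally large gain, whereas a 1.2-fold higher number from compound 1 to compound 3 (0.08 log units; within the scatter) shows cyclopentyl and 5-bromopyridin-2-yl as interchangeable. The ring entering in compound 4 carries propoxy instead of chloro and trifluoromethyl, so the measured aryl case is not a direct match; the expected direction is a weaker number, of uncertain size.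

Compound 4 is therefore expected to show a 54-fold higher number from compound 3 to compound 4 (1.73 log units; beyond the scatter), with an estimated value of 300 nM within a range of 20 nM to 6000 nM.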

Compound 4, inhibition constant: > 10000 nM
Compound 4 was reported as a limit (the forecaster's own chance of this, stated with the estimate: 15%); middle value at least 33-fold (1.52 log units) from the limit.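

In this assay compound 4 is reported only as a limit of the assay, > 10000 nM. The large loss at this carbon now appears with a second six-membered aromatic ring of carbon only, and a second set of substituents: an at least 1700-fold higher number from compound 3 to compound 4 (3.25 log units; beyond the scatter), and an at least 2100-fold higher number from compound 1 to compound 4 (3.32 log units; beyond the scatter), so in the compounds shown the loss is not tied to chloro and trifluoromethyl, since 4-propoxyphenyl, with its propoxy chain and its one hydrogen-bond acceptor, behaves in the same way, while compound 1 stands against any reading that aromatic rings in general fail here, as its 5-bromopyridin-2-yl is aromatic and carries a ring nitrogen. The step from compound 2 to compound 4 cannot be read, as both values are limits: the limit of > 10000 nM in this assay, at which 2 of the 4 values shown sit.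

Still open, going by these compounds, is whether the loss belongs to the carbon-only aromatic ring itself or to what it carries, a question that plain phenyl or 4-methoxyphenyl would address, along with a pyridin-2-yl without bromine on the other side. Also open, on these data alone, is whether a hydroxyl or an amine on the phenyl ring would change the outcome at this carbon.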